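Adding a ring methyl to compound 1: a step forecast

The source may hold more compounds than are shown below. What is called first, only, known or untested is meant among the compounds shown, and "the series" means these compounds.

Compound 1 `CC1CCCN1C1CCN(c2ccc(NC(=O)C3CCCO3)cc2)C1`: 8.7 nM
Compound 2 `Cc1cc(N2CC[C@H](N3CCC[C@@H]3C)C2)ccc1NC(=O)C1C(C)(C)C1(C)C`: 0.55 nM
Compound 3 `Cc1cc(NC(=O)C2CC2)ccc1N1CCC(N2CCCC2C)C1`: 17.7 nM

Of the compounds shown here, three have been measured in an assay on CHO cells for displacement of a labelled ligand from histamine receptor H3 (Macaca mulatta); a higher number here means a weaker inhibitor, a lower number a stronger inhibitor. Compound 1 gives the second highest number of the three; compound 3 sits nearest to it with a higher number, a gap beyond the scatter, while compound 2 lies furthest from it with a far lower number. Compound 4 `Cc1cc(N2CCC(N3CCCC3C)C2)ccc1NC(=O)C1CCCO1` is not yet measured. It differs from compound 1 by methyl in place of hydrogen on an aromatic carbon, placed ortho to a ((oxolan-2-yl)carbonyl)amino group. Among the compounds with values here, no measured pair shows this change alone, since compound 3 and compound 2 carry the methyl together with other amides. Compound 4 is therefore expected to show only a small step, a 1.5-fold lower number from compound 1 to compound 4 (0.16 log units; within the scatter), likely within the scatter. The estimated value of compound 4 is 6 nM, ranging from 2 nM to 20 nM.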

Compound 4, inhibition constant: 7.34 nM
The estimate for compound 4 lay 1.2-fold (0.09 log units) below the measured number; low and high end bracket the measured number.
By their numbers in this assay, from the lowest: compound 2; then compounds 4 and 1 (each within the scatter of the next); then compound 3.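

In this assay, methyl in place of hydrogen on an aromatic carbon, ortho to a ((oxolan-2-yl)carbonyl)amino group, gives a 1.2-fold lower number from compound 1 to compound 4 (0.07 log units; within the scatter). Within the data shown here, this is the first pair to show the methyl alone, and with this amide the added carbon leaves the binding number within the scatter, which compound 2 and compound 3, with their other amides, could not show. Nothing available explains why this position accepts the methyl.

From the compounds shown here alone, whether an ethyl, a methoxy group or a chlorine atom would be accepted at this place remains open. So does whether the methyl has an equally small effect with other amides.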